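Fluoro Gives Way to Methoxy

The source may hold more compounds than are shown below. What is called first, only, known or untested is meant among the compounds shown, and "the series" means these compounds.

Measured in a functional assay on the whole organism (strain Kunming) with Mus musculus as the target, with a stated time of 0.5 h; a lower number here means that less compound is needed, a higher number that more compound is needed for the effect:
- Compound 1 `COc1cc(OC)c(OC)cc1/C=C/COC(=O)/C=C/c1ccccc1C(F)(F)F`: 203 umol/kg
- Compound 2 `COc1cc(OC)c(OC)cc1/C=C/COC(=O)/C=C/c1ccc(F)cc1`: 92.9 umol/kg

Of these two compounds in this assay, compound 2 holds the lower number at 92.9 umol/kg. The next step leads to compound 3 `COc1ccc(/C=C/C(=O)OC/C=C/c2cc(OC)c(OC)cc2OC)cc1`, which carries methoxy in place of fluoro on an aromatic carbon, para to a large group: methoxy in place of fluoro on an aromatic carbon. Within the data shown here, only one measured step bears on this change, and it is modest: a 2.2-fold lower number from compound 1 to compound 2 (0.34 log units; beyond the scatter). That step replaced a different group, 2-(trifluoromethyl)phenyl, so it gives no direction for the move from 4-fluorophenyl to 4-methoxyphenyl. Among the measured compounds shown here, it shows only that a change to this aryl group can shift the number modestly. No step beyond the usual scatter is therefore expected, and the estimated change is a 1.2-fold higher number from compound 2 to compound 3 (0.07 log units; within the scatter). For compound 3 the expected value is 110 umol/kg, with an estimated range from 50 umol/kg to 240 umol/kg.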

Compound 3, dose for half-maximal effect: 184 umol/kg
The estimate for compound 3 lay 1.7-fold (0.22 log units) below the measured number; low and high end bracket the measured number.
By their numbers in this assay, from the lowest: compounds 2, 3 and 1 (each within the scatter of the next, the first and the last beyond it).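

In this assay the exchange of fluoro for methoxy on this aromatic carbon, para to a large group, gives a 2.0-fold higher number from compound 2 to compound 3 (0.30 log units; within the scatter) and so does not separate the two groups. Among these compounds, measured against the 2-(trifluoromethyl)phenyl of compound 1, the 4-methoxyphenyl group gives a 1.1-fold lower number from compound 1 to compound 3 (0.04 log units; within the scatter) while the 4-fluorophenyl group gives a 2.2-fold lower number from compound 1 to compound 2 (0.34 log units; beyond the scatter) so only the step to the 4-fluorophenyl group lies beyond the scatter. Nothing in the data shown accounts for these numbers.

Still open, going by these compounds, is how an amine or a carboxylic acid on this same aromatic carbon would read, and whether a longer chain in place of methoxy would move the number in this assay beyond the scatter from compound 2. Also open, on these data alone, is whether fluoro and methoxy would stay this close on another carbon of the six-membered aromatic ring.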